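Arylsulfonyl piperazine chalcones: bromo to methoxy exchange

This account rests on a few compounds, and the source may have more. Where it says the series, first, only, none or still open, it means among the compounds named here.

Of the compounds shown here, two have a number so far. Compound 1 `O=C(/C=C/c1ccccc1)c1ccc(N2CCN(c3ccccc3F)CC2)cc1` carries a 2-fluorophenyl on the piperazine nitrogen, and in a functional assay on the whole organism (strain Kunming) for inhibition, with Mus musculus as the target, with a stated time of 1 h, at a dose of 40 mg/kg by the oral route (a higher number here means more inhibition at the dose given (going by the name of the read-out), a lower number less inhibition), compound 1 gives 0.57%. Compound 2 `O=C(/C=C/c1ccccc1)c1ccc(N2CCN(S(=O)(=O)c3ccc(Br)cc3)CC2)cc1` carries a (4-bromophenyl)sulfonyl there instead, and in this assay compound 2 gives 47.4%. The step of a number 46.8 percentage points higher from compound 1 to compound 2 (beyond the scatter) is the only one measured, and on the numbers shown compound 2 stands highest of the two, with compound 1 as its only neighbour.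

Compound 3 `COc1ccc(S(=O)(=O)N2CCN(c3ccc(C(=O)/C=C/c4ccccc4)cc3)CC2)cc1` keeps the sulfonyl and differs from compound 2 only on the aromatic ring of that group: methoxy in place of bromo on an aromatic carbon. For the measured compounds named here, no measured step touches this position; the one step known, from a 2-fluorophenyl to a (4-bromophenyl)sulfonyl, changes the group on the piperazine nitrogen as a whole and says nothing about a single substituent on the sulfonyl aryl ring. Going by the values given here, the expectation for compound 3 therefore rests on compound 2 alone, with a wide band and no step in this assay beyond the scatter: a number 7.4 percentage points lower from compound 2 to compound 3 (within the scatter) is the expected change. For compound 3 the estimate in this assay is 40%, ranging from 15% to 65%.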

Compound 3, a percentage reported as inhibition, in the whole organism at one dose (the size of the read-out at that dose, not a potency): 45.2%
Compound 3: the middle estimate sits 5.2 percentage points below what was measured; the range from low to high includes it.
By their numbers in this assay, from the lowest: compound 1; then compounds 3 and 2 (each within the scatter of the next).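

Methoxy in place of bromo on an aromatic carbon, para to a large group, gives a number 2.2 percentage points lower from compound 2 to compound 3 (within the scatter) in this assay, so the two groups cannot be told apart at this position, although methoxy brings one more heavy atom and a hydrogen-bond acceptor that bromo lacks. The other new step, a number 44.6 percentage points higher from compound 1 to compound 3 (beyond the scatter), is of the same order as the one already seen with the bromo compound, which shows that the large difference from the 2-fluorophenyl compound does not depend on bromo being on the sulfonyl aryl ring; it holds for both sulfonyl compounds in hand. There is no measurement here that accounts for either step, or for the lack of a difference between the two substituents.

Still open, from the compounds shown here alone, is whether this position stays as undemanding with a strongly different group, such as an amine, a carboxylic acid or a longer alkoxy chain, or with plain hydrogen in place of bromo. Also open, going by these compounds, is how much of the difference from compound 1 belongs to the sulfonyl itself, which a carbonyl in its place on the amine nitrogen would address.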